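The source may hold more compounds than are shown below. What is called first, only, known or untested is meant among the compounds shown, and "the series" means these compounds.

In a functional assay on PANC-1 cells (Homo sapiens) for cytotoxicity, read by WST assay, with a stated time of 24 h (a higher number here means a weaker inhibitor, a lower number a stronger inhibitor), compound 1 (`O=C(/C=C/CCCCCCc1ccccc1)N[C@H]1CC[C@H](O)CC1`) gives > 100000 nM as a limit. Compound 2 (`O=C(/C=C/CCCCCCc1ccccc1)N1CCC(O)CC1`) gives > 100000 nM as a limit. Compound 3 (`O=C(CCCCCCCCc1ccccc1)N1CCCCC1`) gives > 100000 nM as a limit. For the measured compounds named here, the series so far stands at the limit of > 100000 nM in this assay, at which 3 of the 3 values shown sit, and compound 3 has no number of its own. Compound 4 (`O=C(CCCCCCCCc1cccc(F)c1)N1CCCCC1`) differs from it by fluoro in place of hydrogen on an aromatic carbon and is the phenyl to 3-fluorophenyl change. Going by the values given here, the only measured step is a step that the two limits leave unreadable from compound 1 to compound 2 and it lies elsewhere in the structure, so it gives no size to carry over. The expected change is a number no higher from compound 3 to compound 4 (the limit leaves the size open) and no shift beyond the scatter is expected in either direction. Compound 4 is estimated at 100000 nM with an expected range from 50000 nM to 200000 nM and will probably be reported as a limit again.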

Compound 4, half-maximal inhibitory concentration: > 100000 nM
Compound 4: only a limit was reported (the forecaster's own chance of this, stated with the estimate: 85%); the middle value sits exactly at the limit.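

Compound 3 and compound 4 are both reported only as limits, and no size can be read for fluoro in place of hydrogen on an aromatic carbon. The compounds shown leave open what change in structure, if any, would give a readable number in this assay, where all four stand at one limit: the limit of > 100000 nM in this assay, at which 4 of the 4 values shown sit.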